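Methoxy on the side chain of a trifluoromethoxy analogue

The source may hold more compounds than are shown below. What is called first, only, known or untested is meant among the compounds shown, and "the series" means these compounds.

The measured compounds are:
compound 1, `Cc1nc(Nc2c(Cl)cc(C(F)(F)F)cc2Cl)c(=O)n(C(C)C2CC2)n1`, 14 nM;
compound 2, `COCC(C1CC1)n1nc(C)nc(Nc2c(Cl)cc(C(F)(F)F)cc2Cl)c1=O`, 11 nM;
compound 3, `Cc1nc(Nc2c(Cl)cc(OC(F)(F)F)cc2Cl)c(=O)n(C(C)C2CC2)n1`, 39 nM.

All three were tested in an assay on isolated protein for displacement of a labelled ligand from corticotropin-releasing factor receptor 1 (Rattus norvegicus); a lower number here means a stronger inhibitor, a higher number a weaker inhibitor. Compound 3 holds the highest number of the three; its nearest neighbour is compound 1, and the gap between them is beyond the scatter, as is its gap to compound 2. The step of a 2.8-fold higher number from compound 1 to compound 3 (0.44 log units; beyond the scatter) shows what the trifluoromethoxy group in place of trifluoromethyl cost.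

Compound 4 is `COCC(C1CC1)n1nc(C)nc(Nc2c(Cl)cc(OC(F)(F)F)cc2Cl)c1=O`. It differs from compound 3 by methoxy in place of hydrogen on a saturated chain carbon, two bonds along the chain from an aromatic nitrogen and a saturated ring carbon. The same change has been measured once already, on the trifluoromethyl pair: a 1.3-fold lower number from compound 1 to compound 2 (0.10 log units; within the scatter), a step that stays within the scatter. Among the measured compounds shown here, no other step bears on the change, and nothing in the data suggests that the trifluoromethoxy series should respond differently from the trifluoromethyl series.

The account therefore expects no step beyond the scatter in this assay; the expected step is a 1.2-fold lower number from compound 3 to compound 4 (0.07 log units; within the scatter). Compound 4 is estimated at 33 nM, with a range from 15 nM to 75 nM.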

Compound 4, half-maximal inhibitory concentration: 11 nM
Compound 4: the middle estimate sits 3.0-fold (0.48 log units) above what was measured; measured number outside the range, below it.
By their numbers in this assay, from the lowest: compounds 2, 4 and 1 (each within the scatter of the next); then compound 3.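

In this assay, the methoxy change does not have one fixed size; its step depends on the group on the aromatic carbon. On the trifluoromethoxy core it gives a 3.5-fold lower number from compound 3 to compound 4 (0.55 log units; beyond the scatter), which is not what it gave on the trifluoromethyl core: the same change on two cores in this assay, a 1.3-fold lower number (0.10 log units; within the scatter) from compound 1 to compound 2 and a 3.5-fold lower number (0.55 log units; beyond the scatter) from compound 3 to compound 4, 2.8-fold (0.44 log units) apart, beyond the scatter of two such steps

The reverse reading holds as well. Once the side chain is 1-cyclopropyl-2-methoxyethyl, exchanging trifluoromethyl for trifluoromethoxy gives no change at the digits printed from compound 2 to compound 4 (within the scatter), so the loss seen with the 1-cyclopropylethyl side chain does not appear: the same change on two cores in this assay, a 2.8-fold higher number (0.44 log units; beyond the scatter) from compound 1 to compound 3 and no change at the digits printed (within the scatter) from compound 2 to compound 4, 2.8-fold (0.44 log units) apart, beyond the scatter of two such steps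

The two changes therefore do not add up independently in these four compounds, and methoxy on this saturated chain carbon matters only where trifluoromethoxy is present.

This dependence rests on a single square of compounds, and the values do not say why the two changes interact. From the compounds shown here alone, it remains open whether a hydroxy or an ethoxy in place of the methoxy would behave the same way, and whether the dependence would persist with a chlorine or a nitrile in place of trifluoromethyl or trifluoromethoxy on the aromatic carbon.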